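A few compounds are considered here, and "the series" means these few. Any claim that something is new, unique, unknown or untested is made for them only; others in the source may bear on it.

Working notes on the series. The shared core of compound 2 `CCC(=O)N(Cc1ccc(OC)c(O)c1)c1cc(OC)c(OC)c(OC)c1` carries a propanoyl group on the amide nitrogen. Going by the values given here, in a functional assay on HCT-116 cells (Homo sapiens) for inhibition, read by MTT assay, with a stated time of 48 h (a lower number here means a stronger inhibitor, a higher number a weaker inhibitor), compound 2 gives 61 nM, which places it second highest of the three numbers measured so far. Its nearest neighbour is compound 3 `COc1ccc(CN(C(=O)C2CC2)c2cc(OC)c(OC)c(OC)c2)cc1O`, in which cyclopropyl stands in place of ethyl on the carbonyl carbon; in this assay compound 3 gives 49 nM, and the change reads a 1.2-fold lower number from compound 2 to compound 3 (0.10 log units; within the scatter). The furthest is compound 1 `C/C=C/C(=O)N(Cc1cccc(O)c1)c1cc(OC)c(OC)c(OC)c1`, which differs in several places at once and in this assay gives 6700 nM, the two values showing a gap beyond the scatter.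

Compound 4 `COc1ccc(CN(C(=O)CCl)c2cc(OC)c(OC)c(OC)c2)cc1O` differs from compound 2 in one place: chloro in place of methyl on a saturated chain carbon bound to a carbonyl carbon. Among the compounds with values here, only one measured step changes the acyl group, a 1.2-fold lower number from compound 2 to compound 3 (0.10 log units; within the scatter), and it stayed within the scatter; no measured step exchanges a methyl for a chloro anywhere, so a direct precedent is absent. The expectation therefore rests on the acyl variation seen so far: no step beyond the scatter in this assay is expected, and the estimated change is a 1.3-fold higher number from compound 2 to compound 4 (0.12 log units; within the scatter). For compound 4 the value in this assay is estimated at 80 nM, with an expected range from 25 nM to 300 nM.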

Compound 4, half-maximal inhibitory concentration: 250 nM
Compound 4: middle estimate off by 3.1-fold (0.49 log units), on the low side; the measured number falls inside the stated range.
By their numbers in this assay, from the lowest: compounds 3 and 2 (each within the scatter of the next); then compound 4; then compound 1.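

In this assay, going by these compounds alone, the acyl group on the amide nitrogen turns out not to be indifferent to every exchange: chloro in place of methyl on a saturated chain carbon bound to a carbonyl carbon gives a step beyond the scatter (a 4.1-fold higher number from compound 2 to compound 4 (0.61 log units; beyond the scatter)), whereas the only earlier change at this place stayed within it (a 1.2-fold lower number from compound 2 to compound 3 (0.10 log units; within the scatter)). The comparison with the cyclopropyl amide reads the same way (a 5.1-fold higher number from compound 3 to compound 4 (0.71 log units; beyond the scatter)), so among compounds 2, 3 and 4 the chloromethyl group is the one acyl substituent that separates from the other two, and neither of those two goes against this. Nothing at hand bears on the cause of this step.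

The compounds shown leave open whether the higher number belongs to chloro specifically or would also follow from a fluoro, a methoxy or an amine on the same saturated chain carbon. Within the data shown here, also open is how a longer chain or a carboxylic acid on the carbonyl carbon would read against the ethyl and cyclopropyl amides, so the tolerated range of this position remains defined by only three acyl groups.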